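Triazole amide series: benzyl in place of aryl on ring nitrogen

This account rests on a few compounds, and the source may have more. Where it says the series, first, only, none or still open, it means among the compounds named here.

Values in a functional assay on MCF7 cells (Homo sapiens) for inhibition, read by MTT assay, with a stated time of 72 h (on this read-out higher numbers stand for weaker inhibition and lower numbers for stronger inhibition), for the three measured compounds:
compound 1, `CC(C)n1ncc2c(C(=O)NCc3cn(-c4ccccc4)nn3)cccc21`, gives > 40000 nM, which is a limit of the assay.
compound 2, `Cc1ccc(-n2cc(CNC(=O)c3cccc4c3cnn4C(C)C)nn2)cc1C`, gives > 40000 nM, which is a limit of the assay.
compound 3, `Cc1cccc(-n2cc(CNC(=O)c3cccc4c3cnn4C(C)C)nn2)c1`, gives > 40000 nM, which is a limit of the assay.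

Compound 3 therefore stands at the same limit as the two other measured compounds, and no number among the three is a real reading: all sit at the limit of > 40000 nM in this assay, at which 3 of the 3 values shown sit. From the compounds shown here alone, the measured steps give nothing to read, as a step that the two limits leave unreadable from compound 1 to compound 2, a step that the two limits leave unreadable from compound 1 to compound 3 and a step that the two limits leave unreadable from compound 2 to compound 3 are each bounded on both sides by the limit, so their size and direction remain unknown.

Compound 4 is `CC(C)n1ncc2c(C(=O)NCc3cn(Cc4ccc(C#N)cc4)nn3)cccc21`. Relative to compound 3 the change is 4-cyanobenzyl in place of 3-methylphenyl on an aromatic nitrogen. Within the data shown here, no measured step in this assay concerns a benzyl group on the ring nitrogen, and the aryl-to-aryl steps among compounds 1, 2 and 3 are unreadable, so there is no measured basis for a step of any particular size or direction. The expectation for compound 4 in this assay is accordingly that it most likely again reaches only the limit, with an expected step that the limit leaves unreadable from compound 3 to compound 4. The estimate for compound 4 is 50000 nM, with a range from 10000 nM to 200000 nM, and the expectation that the assay reports a limit rather than a number is high.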

Compound 4, half-maximal inhibitory concentration: > 40000 nM
Compound 4 gave a limit, no number; the forecaster's own chance of this, stated with the estimate: 70%; the middle value is on the limit's open side.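

In this assay compound 4 gives > 40000 nM, which is a limit of the assay. The steps to compound 4 from compound 1, compound 2 and compound 3 therefore cannot be read: the limit of > 40000 nM in this assay, at which 4 of the 4 values shown sit.

The compounds shown leave open whether any group on the aromatic nitrogen gives a real reading in this assay, and how phenyl, 3-methylphenyl, 3,4-dimethylphenyl and 4-cyanobenzyl rank against one another.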